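A few compounds are considered here, and "the series" means these few. Any claim that something is new, unique, unknown or untested is made for them only; others in the source may bear on it.

Compound 1, `CC(=O)OCc1cc2c(c(O)c1O)[C@H](C)C[C@@H](OC(C)=O)[C@H]2[C@@H](C)CCC=C(C)C`: 80000 nM
Compound 2, `CC(C)=CCC[C@H](C)[C@H]1c2cc(C(=O)NCc3ccc(Cl)cc3)c(OC(=O)C(C)(C)C)c(OC(=O)C(C)(C)C)c2[C@H](C)C[C@H]1OC(=O)C(C)(C)C`: 40000 nM
Compound 3, `CC(C)=CCC[C@H](C)[C@H]1c2cc(C(=O)NCCN(C)C)c(OC(=O)C(C)(C)C)c(OC(=O)C(C)(C)C)c2[C@H](C)C[C@H]1OC(=O)C(C)(C)C`: 14600 nM

These three compounds share one core and were tested in an ADME assay on HEK293 cells (Homo sapiens) for inhibition, read by resazurin assay, with a stated time of 72 h; a lower number here means a stronger inhibitor, a higher number a weaker inhibitor. Compound 2 holds the second highest of the three numbers. Its nearest neighbour is compound 1, whose number lies within the usual scatter of that of compound 2, so the two cannot be set in order. Within the data shown here, the only change between measured compounds that touches a single place is a 2.7-fold lower number from compound 2 to compound 3 (0.44 log units; beyond the scatter), a modest gain that lies beyond the scatter.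

Compound 4, `CC(C)=CCC[C@H](C)[C@H]1c2cc(C(=O)O)c(OC(=O)C(C)(C)C)c(OC(=O)C(C)(C)C)c2[C@H](C)C[C@H]1OC(=O)C(C)(C)C`, is the compound not yet measured. Relative to compound 2 it carries hydroxy in place of (4-chlorobenzyl)amino on a carbonyl carbon. The step from compound 2 to compound 3 is the only measured one that alters the same part of the molecule, the group on the carbonyl carbon, and it lowered the number modestly when one group replaced another on the amide-type nitrogen. Among the measured compounds shown here, no measured step removes the amide-type nitrogen altogether, as this change does, so the data give no direct guide. The expectation for compound 4 is therefore cautious: a step of a 1.5-fold higher number from compound 2 to compound 4 (0.18 log units; within the scatter) is estimated, toward a weaker inhibitor but not far beyond the scatter. Compound 4 is expected to give about 60000 nM in this assay, between 25000 nM and 150000 nM.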

Compound 4, half-maximal inhibitory concentration: 40000 nM
Compound 4: the middle estimate sits 1.5-fold (0.18 log units) above what was measured, within the range that was stated.
By their numbers in this assay, from the lowest: compound 3; then compounds 2, 4 and 1 (each within the scatter of the next).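

In this assay, putting hydroxy in place of (4-chlorobenzyl)amino on the carbonyl carbon gives no change at the digits printed from compound 2 to compound 4 (within the scatter) and so shows that this large change, which removes the amide-type nitrogen and the chlorine-bearing aromatic ring, leaves the reading unmoved. Among these compounds, putting hydroxy in place of (2-(dimethylamino)ethyl)amino at that same carbon gives a 2.7-fold higher number from compound 3 to compound 4 (0.44 log units; beyond the scatter) and so adds a second comparison to the single step known before: compound 3 now differs beyond the scatter from both compound 2 and compound 4, whose own numbers cannot be set in order. Among these three groups on the carbonyl carbon, then, only the (2-(dimethylamino)ethyl)amino group sets its compound apart, and no measurement shown here explains why.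

Going by these compounds, it remains open whether the lower number of compound 3 depends on the dimethylamino end or on the two-carbon chain that carries it. A longer chain ending in the same dimethylamino group, or a morpholine at the end of the same chain, would help separate these two parts of the group.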